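The source may hold more compounds than are shown below. What is called first, only, known or untested is meant among the compounds shown, and "the series" means these compounds.

Compound 2 `CCc1nc(C)c(CN2CCN(c3cccc4[nH]c(-c5ccc(C(C)(C)C)cc5)nc34)CC2)o1` is the point of departure. Within the data shown here, in an assay on isolated protein for displacement of a labelled ligand from Gonadotropin-releasing hormone receptor (Homo sapiens) (on this read-out lower numbers stand for stronger inhibition and higher numbers for weaker inhibition), compound 2 gives 37 nM, the second highest of the three numbers so far measured. Its nearest neighbour is compound 3 `CCc1nc(C)c(CN2CCN(c3cccc4[nH]c(-c5ccc(C(C)(C)C)cc5)nc34)CC2)s1`, which gives in this assay 20 nM, so that the step of a 1.9-fold lower number from compound 2 to compound 3 (0.27 log units; within the scatter) stays within the scatter. The furthest is compound 1 `Cc1ccc(CN2CCN(c3cccc4[nH]c(-c5ccc(C(C)(C)C)cc5)nc34)CC2)o1`, which gives in this assay 705 nM; the step of a 19-fold lower number from compound 1 to compound 2 (1.28 log units; beyond the scatter) is large, as is the step of a 35-fold lower number from compound 1 to compound 3 (1.55 log units; beyond the scatter).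

Compound 4 `CCc1nc(CN2CCN(c3cccc4[nH]c(-c5ccc(C(C)(C)C)cc5)nc34)CC2)cn1C` differs from compound 2 at one place: 2-ethyl-1-methyl-1H-imidazol-4-yl in place of 2-ethyl-4-methyl-1,3-oxazol-5-yl on a saturated chain carbon bound to an amine nitrogen in a ring. The measured step that bears most directly on this is the exchange of one five-membered ring with 2 hetero atoms for another between compound 2 and compound 3, which moved the number only within the scatter; the two large steps both concern leaving the 5-methylfuran-2-yl ring, which compound 4 also lacks. The analyst therefore expects no step beyond the scatter, estimating a 1.1-fold lower number from compound 2 to compound 4 (0.02 log units; within the scatter). The estimate for compound 4 in this assay is 35 nM, expected to lie between 10 nM and 120 nM.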

Compound 4, half-maximal inhibitory concentration: 18 nM
Beside the measured number, compound 4's estimate is 1.9-fold (0.29 log units) above it; the range from low to high includes it.
By their numbers in this assay, from the lowest: compounds 4, 3 and 2 (each within the scatter of the next, the first and the last beyond it); then compound 1.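

In this assay, this position on a saturated chain carbon bound to an amine nitrogen in a ring now shows a step beyond the scatter between two rings of the same size and heavy-atom count: a 2.1-fold lower number from compound 2 to compound 4 (0.31 log units; beyond the scatter) is modest, while a 1.1-fold lower number from compound 3 to compound 4 (0.05 log units; within the scatter) stays within the scatter. With a 39-fold lower number from compound 1 to compound 4 (1.59 log units; beyond the scatter) as a further large step, a third ethyl-bearing ring stands well apart from the 5-methylfuran-2-yl ring, and the differences among these three ethyl-bearing rings remain small by comparison. Nothing at hand accounts for these differences.

From the compounds shown here alone, the ethyl group never changes alone in these compounds, so its own contribution stays open, and a propyl chain or a cyclopropyl group in its place would test it. Going by these compounds, whether a six-membered ring such as pyridine could serve at this place also remains open.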